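Replacing the 4-methoxyphenyl group of compound 2

A few compounds are considered here, and "the series" means these few. Any claim that something is new, unique, unknown or untested is made for them only; others in the source may bear on it.

Measured in an ADME assay on Vero cells (Chlorocebus sabaeus) for cytotoxicity, read by fluorescence and resazurin assay, with a stated time of 72 h; a lower number here means a stronger inhibitor, a higher number a weaker inhibitor:
- Compound 1 `O=C(NCc1ccc(N2CCC(c3ccc(OC(F)(F)F)cc3)CC2)cc1)c1sc2c([N+](=O)[O-])cc(C(F)(F)F)cc2[n+]1[O-]`: 81000 nM
- Compound 2 `COc1ccc(CNC(=O)c2sc3c([N+](=O)[O-])cc(C(F)(F)F)cc3[n+]2[O-])cc1`: 76000 nM
- Compound 3 `CC(C)(C)OC(=O)N1CCC(Oc2ccc(Nc3ccc([N+](=O)[O-])cc3C#N)cc2)CC1`: > 100000 nM, a limit of the assay and not a number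

Compound 2 gives 76000 nM and compound 1 gives 81000 nM, so the two lie within the usual scatter of each other. Compound 3 gives only a limit, > 100000 nM. This leaves compound 2 with a single numerical neighbour.

Compound 4 `O=C(NCc1ccc2c(c1)CCO2)c1sc2c([N+](=O)[O-])cc(C(F)(F)F)cc2[n+]1[O-]` keeps the shared core of compound 2 and changes on a saturated chain carbon bound to an amide-type nitrogen: a group of 9 heavy atoms (8 carbon, 1 oxygen; one five-membered non-aromatic ring with 1 hetero atom, one six-membered aromatic ring of carbon only) in place of a group of 8 heavy atoms (7 carbon, 1 oxygen; one six-membered aromatic ring of carbon only), on a saturated chain carbon bound to an amide-type nitrogen. The 4-methoxyphenyl group leaves, and the group that enters carries a five-membered non-aromatic ring as well as its six-membered aromatic ring.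

For the measured compounds named here, no measured pair shows this change directly. Because compound 1 gives 81000 nM with a different group on the shared core, within the scatter of compound 2, no step beyond the scatter is expected in this assay. The expected step is a 1.0-fold lower number from compound 2 to compound 4 (0.01 log units; within the scatter). For compound 4 the estimated value is 75000 nM, with an expected range of 35000 nM to 100000 nM.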

Compound 4, half-maximal inhibitory concentration: > 100000 nM
Compound 4: no number, only a limit; the forecaster's own chance of this, stated with the estimate: 25%; middle value at least 1.3-fold (0.12 log units) away from the limit.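

In this assay, replacing 4-methoxyphenyl with the group that carries a five-membered non-aromatic ring, on a saturated chain carbon bound to an amide-type nitrogen, gives an at least 1.3-fold higher number from compound 2 to compound 4 (0.11 log units; that floor lies within the scatter) and so sets only a floor for this change. Compound 4 gives > 100000 nM, a limit of the assay and not a number. The change therefore gives no step beyond the scatter, and its true size cannot be read because compound 4 sits at the limit of the assay: the limit of > 100000 nM in this assay, at which 2 of the 4 values shown sit.

The compounds shown leave open what a group outside this series would give on the same chain carbon. A carboxylic acid or an amine there might bring the value within the measurable range, or might also reach the limit.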